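Adding an acetyl to a weakly cytotoxic series

The source may hold more compounds than are shown below. What is called first, only, known or untested is meant among the compounds shown, and "the series" means these compounds.

Measured in a functional assay on K562 cells (Homo sapiens) for cytotoxicity, read by MTT assay, with a stated time of 48 h (on this read-out lower numbers stand for stronger inhibition and higher numbers for weaker inhibition), so far:
compound 1 `COc1ccc(-c2c[nH]c(=O)n2-c2cc(OC)c(OC)c(OC)c2)cc1OC` gives "not determined" (no result reported)
compound 2 `COc1ccc(-c2c[nH]c(=O)n2-c2cc(OC)c(OC)c(OC)c2)cc1[N+](=O)[O-]` gives "not determined" (no result reported)
compound 3 `COc1ccc(-c2c[nH]c(=O)n2-c2cc(OC)c(OC)c(OC)c2)cc1N` gives 49200 nM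

Compound 1 has no single number to stand on, and compound 2 shares that gap, so only compound 3 offers a measured level. Compound 4 `COc1ccc(-c2cn(C(C)=O)c(=O)n2-c2cc(OC)c(OC)c(OC)c2)cc1OC` keeps the core of compound 1 and carries acetyl in place of hydrogen on an aromatic nitrogen. With no measured starting point, and no comparable change among these compounds, no direction can be argued, so no step beyond the scatter is expected in this assay. For the measured compounds named here, the only anchor is compound 3 at 49200 nM, a weak result. For compound 4 the estimate is 35000 nM, with an expected range from 8000 nM to 100000 nM.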

Compound 4, half-maximal inhibitory concentration: 43400 nM
Compound 4: the middle estimate sits 1.2-fold (0.09 log units) below what was measured; measured number inside the range.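

Compound 1 has no single number to compare with compound 4, so no step can be read from this pair. Whether acetyl in place of hydrogen on the aromatic nitrogen shifts the result in this assay stays open, and no further data shown here bear on it.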